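The compounds below may be only part of what the source reports. "The series", "measured", "known", "first", "only" and "open" are said of these compounds alone.

Measured so far in a functional assay on DMS-114 cells (Homo sapiens) for inhibition, read by sulforhodamine B assay, with a stated time of 48 h; on this read-out lower numbers stand for stronger inhibition of growth and higher numbers for weaker inhibition of growth:
- compound 1 `Cc1cn([C@H]2C[C@H](CC3=CC(=O)C(=O)C=C3)[C@@H](CO[Si](C)(C)C(C)(C)C)O2)c(=O)[nH]c1=O`: no result reported
- compound 2 `COc1ccc(C2([C@H]3C[C@H](n4cc(C)c(=O)[nH]c4=O)O[C@@H]3CO[Si](C)(C)C(C)(C)C)SCCCS2)cc1OC`: 3310 nM

For the measured compounds named here, compound 2 at 3310 nM holds the only number in this set. Going by the values given here, with no result for compound 1, there is no ranking to draw and no measured step to calibrate against.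

Still unmeasured is compound 3 `COc1ccc(C2([C@H]3C[C@@H](n4cc(C)c(=O)[nH]c4=O)O[C@@H]3CO[Si](C)(C)C(C)(C)C)SCCCS2)cc1OC`. Set against compound 2, compound 3 shows the two compounds have the same atoms and bonds and differ only in configuration as drawn: 1 of 3 stereo elements differ; a stereocentre at a saturated ring carbon is drawn R in compound 2 and S in compound 3 and no other change. The stereocentre concerned sits at a saturated ring carbon, drawn R in compound 2 and S in compound 3.

Among the compounds with values here, the data hold no pair showing what such a change in configuration does in this assay, so no firm direction can be argued. The expectation is therefore no step beyond the usual scatter, anchored only on compound 2 at 3310 nM and kept deliberately wide. The expected change is a 1.2-fold higher number from compound 2 to compound 3 (0.08 log units; within the scatter) and is estimated as a small one. For compound 3 the expected value is 4000 nM (estimated range 1500 nM to 11000 nM).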

Compound 3, concentration for 50% growth inhibition: 5620 nM
Compound 3: the middle estimate sits 1.4-fold (0.15 log units) below what was measured; low and high end bracket the measured number.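

In this assay, for the compounds shown here, this is the first measured pair at this stereocentre on a saturated ring carbon, and it gives a 1.7-fold higher number from compound 2 to compound 3 (0.23 log units; within the scatter). Drawing this carbon R or S therefore does not separate the two compounds on this read-out, at least with the rest of the structure held fixed. Before this pair, the series offered a single number and no step, whereas it now has one calibration point for a change in configuration, and that step can be assigned to a single structural difference: the fact that compounds 2 and 3 differ only in the configuration as drawn

A single pair covers only one of the three stereo elements and only one set of substituents, so it cannot show whether the other two stereo elements are equally tolerated or whether the same result would hold elsewhere in the series. Also open, as far as these compounds go, is whether this stereocentre would matter more if the silyl ether gave way to a free hydroxyl or an amine, since a result that holds with the silyl ether in place need not carry over to either group.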